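The compounds below may be only part of what the source reports. "The series", "measured", "known", "first", "only" and "open" are said of these compounds alone.

Measured so far in an assay on HEK293 cells for inhibition of N-acylethanolamine-hydrolyzing acid amidase (Rattus norvegicus), read by LC-MS, with a stated time of 30 min; a higher number here means a weaker inhibitor, a lower number a stronger inhibitor:
Compound 1, `Cc1ccccc1-c1ccc(CCC(=O)N2CCCC2)cc1`, gives > 100000 nM; this value is a limit of the assay.
Compound 2, `Cc1cccc(-c2ccc(CCC(=O)N3CCCC3)cc2)c1`, gives 16500 nM.
Compound 3, `O=C(CCc1ccc(-c2ccccc2Cl)cc1)N1CCCC1`, gives > 100000 nM; this value is a limit of the assay.

Compound 3 therefore stands at a limit, not at a number, and it shares that limit with one other value shown (the limit of > 100000 nM in this assay, at which 2 of the 3 values shown sit). Compound 4, `O=C(CCc1ccc(-c2ccsc2)cc1)N1CCCC1`, is the next compound to be measured. It differs from compound 3 in one place: thiophen-3-yl in place of 2-chlorophenyl on an aromatic carbon.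

Within the data shown here, none of the measured steps changes a phenyl ring for a thiophene, so the guidance is indirect. The step of an at least 6.0-fold lower number from compound 1 to compound 2 (0.78 log units; beyond the scatter) and the step of an at least 6.0-fold higher number from compound 2 to compound 3 (0.78 log units; beyond the scatter) both show that moving away from a 2-substituted phenyl on this aromatic carbon, or back to one, shifts the value beyond the scatter. The step that the two limits leave unreadable from compound 1 to compound 3 adds nothing readable.

Since compound 3 sits at a limit, a lower number for compound 4 cannot be excluded and, given that the unsubstituted thiophen-3-yl leaves the 2-substituted pattern behind, a modest improvement is expected. Compound 4 is expected to give 30000 nM, in the range 5000 nM to 150000 nM. This expectation corresponds to a step of an at least 3.3-fold lower number from compound 3 to compound 4 (0.52 log units; beyond the scatter).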

Compound 4, half-maximal inhibitory concentration: 2500 nM
Estimate against measurement, compound 4: 12-fold (1.08 log units) above, outside the stated range (below it).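

Compound 4 is the strongest of the four in this assay, so a six-membered aromatic ring of carbon only is not required on this aromatic carbon. Among these compounds, measured against the only earlier compound with a number, the change gives a 6.6-fold lower number from compound 2 to compound 4 (0.82 log units; beyond the scatter) and shows that a five-membered aromatic ring with 1 hetero atom can surpass 3-methylphenyl here. The steps of an at least 40-fold lower number from compound 3 to compound 4 (1.60 log units; beyond the scatter) and an at least 40-fold lower number from compound 1 to compound 4 (1.60 log units; beyond the scatter) give only minimum sizes, as compound 1 and compound 3 each stand at a limit: the limit of > 100000 nM in this assay, at which 2 of the 4 values shown sit.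

The compounds shown leave open whether the ring size or the hetero atom carries the gain, a question on which an unsubstituted phenyl or a thiophen-2-yl on this carbon would bear. Also open, as far as these compounds go, is whether an amine or a carboxylic acid on the thiophene would keep it.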